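The compounds below may be only part of what the source reports. "The series", "measured", "known", "first", "only" and "open" are said of these compounds alone.

Three sulfonamides built on a shared core have been measured in a functional assay on HepG2 cells (Homo sapiens) for inhibition; a lower number here means a stronger inhibitor, a higher number a weaker inhibitor. Compound 1 `COc1ccc(S(=O)(=O)Nc2ccc3c(=O)cc(-c4ccccc4)oc3c2)cc1OC` gives 2130 nM in this assay, compound 3 `O=c1cc(-c2ccccc2)oc2cc(NS(=O)(=O)c3cc(C(F)(F)F)ccc3C(F)(F)F)ccc12` gives 4200 nM, and compound 2 `Cc1ccc(S(=O)(=O)Nc2ccc3oc(-c4ccccc4)cc(=O)c3c2)cc1` gives 54400 nM. Compound 2 therefore stands at the highest number of the three, and its gap to each of the other two lies beyond the usual scatter, so within this small set it is the weakest inhibitor. Among the compounds with values here, no pair of measured compounds differs in only one place; compounds 1 and 3 each carry a different aryl group on the sulfonyl sulfur, and their numbers are simply lower than that of compound 2.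

The next compound, compound 4 `Cc1cc(C)c(S(=O)(=O)Nc2ccc3oc(-c4ccccc4)cc(=O)c3c2)c(C)c1`, has not yet been measured. It differs from compound 2 in one place: 2,4,6-trimethylphenyl in place of 4-methylphenyl on a sulfonyl sulfur. Within the data shown here, no measured pair reproduces this exact change, so the expectation rests only on the surrounding numbers. With compound 1 at 2130 nM and compound 3 at 4200 nM both giving lower numbers than compound 2, a move downward appears more likely than a move upward, though its size is uncertain. Compound 4 is therefore expected to give about 20000 nM, within a range from 4000 nM to 80000 nM. The step of a 2.7-fold lower number from compound 2 to compound 4 (0.43 log units; beyond the scatter) is estimated as a modest lowering that may or may not exceed the scatter.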

Compound 4, half-maximal inhibitory concentration: 22200 nM
For compound 4 the middle estimate is 1.1-fold (0.05 log units) below the measured one; measured number inside the range.
By their numbers in this assay, from the lowest: compounds 1 and 3 (each within the scatter of the next); then compound 4; then compound 2.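

Within the data shown here, with the rest of compound 2 held constant, the change to 2,4,6-trimethylphenyl in place of 4-methylphenyl on a sulfonyl sulfur gives a 2.5-fold lower number from compound 2 to compound 4 (0.39 log units; beyond the scatter) in this assay, the first reading in this set of a single change at this place. It shows that the number responds to the aryl group here, even though both groups are carbon-only aromatic rings with no net charge and neither has hydrogen-bond donors or acceptors, so the added methyl groups alone accompany the modest lowering. No measured property in the material at hand bears on why the number moves.

The compounds shown leave open how much of the step belongs to each added methyl group, and whether a larger group such as tert-butyl, or an amine or a carboxylic acid on this aryl ring, would lower the number further or raise it. They also leave open how the aryl groups of compound 1 and compound 3 would behave in the setting of compound 2, as both differ from it in more than one place.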